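The source may report more compounds than this note shows. Statements on the series, on what has been measured and on what is new or still open speak of the compounds shown alone.

Compound 1 `CN1CCN(CC(=O)NC2CC3(N4CCCC4)CC(c4ccccc4)C2C(c2ccccc2)C3)CC1`: 50200 nM
Compound 2 `CN1CCN(CC(=O)NC2CC3(N(C)C)CC(c4ccccc4)C2C(c2ccccc2)C3)CC1`: 66200 nM

Of the compounds shown here, two have so far been measured in an ADME assay on L6 cells (Rattus norvegicus) for cytotoxicity, read by resazurin assay, with a stated time of 72 h; on this read-out higher numbers stand for weaker inhibition and lower numbers for stronger inhibition. Compound 1 gives 50200 nM in this assay, the lowest of the two numbers, and compound 2 gives 66200 nM. For the measured compounds named here, the single measured step, a 1.3-fold higher number from compound 1 to compound 2 (0.12 log units; within the scatter), lies within the scatter, so the two values cannot be placed in any order.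

Compound 3 `NCC(=O)OC1CC2(N3CCCC3)CC(c3ccccc3)C1C(c1ccccc1)C2` has not yet been measured. It differs from compound 1 at another place on the shared core: ((aminomethyl)carbonyl)oxy in place of (((4-methylpiperazin-1-yl)methyl)carbonyl)amino on a saturated ring carbon. Going by the values given here, the one measured step concerns a different group on the core, so no measured step bears directly on this change; what the two measured values show is only that altering one substituent on the core left the number within the scatter. On that basis compound 3 is expected to remain close to compound 1, with the expected step of a 1.1-fold lower number from compound 1 to compound 3 (0.05 log units; within the scatter) not reaching beyond the scatter in either direction. The estimate for compound 3 in this assay is 45000 nM, with a range from 15000 nM to 130000 nM.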

Compound 3, half-maximal inhibitory concentration: 42900 nM
Beside the measured number, compound 3's estimate is 1.0-fold (0.02 log units) above it; low and high end bracket the measured number.
By their numbers in this assay, from the lowest: compounds 3, 1 and 2 (each within the scatter of the next).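

In this assay, for the compounds shown here, this is the first measured change at this saturated ring carbon of the shared core, and the step, a 1.2-fold lower number from compound 1 to compound 3 (0.07 log units; within the scatter), shows that this place tolerates a large exchange of substituent without the number leaving the scatter. The group that leaves holds 11 heavy atoms and a six-membered non-aromatic ring with 2 hetero atoms, whereas the group that enters holds 5 heavy atoms and no ring, so neither the ring nor the 4-methylpiperazin-1-yl group is needed to keep the number within the scatter of compound 1. Nothing available explains why the number stays within the scatter.

The compounds shown do not separate the change from amino to oxy at the ring carbon from the loss of the 4-methylpiperazin-1-yl group, as both occur together in the one step, and an aminomethyl carbonyl group joined through an amino link would tell the two apart. Also open, going by these compounds, is whether a carboxylic acid or a longer chain at this ring carbon would likewise stay within the scatter of compound 1.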